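Moving the Indole Attachment Point on Compound 1

This account rests on a few compounds, and the source may have more. Where it says the series, first, only, none or still open, it means among the compounds named here.

Compound 1 `Cn1c(=O)c(S(=O)(=O)c2ccc(F)cc2)cc2cnc(Nc3ccc4cc[nH]c4c3)nc21`: 10000 nM
Compound 2 `Cn1c(=O)c(S(=O)(=O)c2ccc(F)cc2F)cc2cnc(Nc3cccc4[nH]ccc34)nc21`: 750 nM

In a functional assay on DU-145 cells (Homo sapiens) for inhibition, read by trypan blue exclusion, with a stated time of 72 h (on this read-out higher numbers stand for weaker inhibition and lower numbers for stronger inhibition), compound 1 has the higher number of the two, and the gap down to compound 2 lies beyond the usual scatter. Compound 3 `Cn1c(=O)c(S(=O)(=O)c2ccc(F)cc2)cc2cnc(Nc3ccc4[nH]ccc4c3)nc21` changes one thing in compound 1: 1H-indol-5-yl in place of 1H-indol-6-yl on a nitrogen on an aromatic ring. Going by the values given here, no measured pair shows this change alone, and compound 2 differs from compound 1 in more than one place. A moderate fall is expected, an estimated step of a 4.0-fold lower number from compound 1 to compound 3 (0.60 log units; beyond the scatter). The estimate for compound 3 is 2500 nM, with an expected range from 500 nM to 10000 nM.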

Compound 3, half-maximal inhibitory concentration: 300 nM
Compound 3: the middle estimate sits 8.3-fold (0.92 log units) above what was measured, and the stated range ends above it.
By their numbers in this assay, from the lowest: compound 3; then compound 2; then compound 1.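

In this assay, compound 1 and compound 3 hold the same atoms, so the indole attachment point alone separates them: 1H-indol-5-yl in place of 1H-indol-6-yl on the nitrogen gives a large step (a 33-fold lower number from compound 1 to compound 3 (1.52 log units; beyond the scatter)). This position therefore responds strongly to how the indole is joined, not only to whether an indole is present. Nothing measured here explains the step.

Still open, going by these compounds, is whether the gain from 1H-indol-5-yl would survive a change to that group, such as adding a carboxylic acid or an amine to it.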